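The source may report more compounds than this note shows. Statements on the series, on what has been measured and on what is new or still open speak of the compounds shown alone.

For the measured compounds named here, compound 3 `Cc1ccccc1-c1ccc(N(C[C@@H](N)CC(C)C)C(=O)[C@@H]2C[C@H]2c2ccccc2)cc1` gives 3400 nM in a functional assay for agonist activity at G protein-coupled receptor 88 (Homo sapiens), read by HTRF and cAMP accumulation (a higher number here means that more compound is needed for the effect, a lower number that less compound is needed), the highest of the three numbers measured so far. Compound 2 `CC(C)C[C@H](N)CN(C(=O)[C@@H]1C[C@H]1c1ccccc1)c1ccc(C2=CCCC2)cc1` gives 1200 nM, and compound 1 `O=C([C@@H]1C[C@H]1c1ccccc1)N(CCNCC1CCCC1)c1ccc(-c2ccccc2)cc1` gives 2.5 nM. Compound 4 `CC(C)C[C@H](N)CN(C(=O)[C@@H]1C[C@H]1c1ccccc1)c1ccc(-c2ccc(Cl)cc2)cc1` has not yet been measured. The change is 4-chlorophenyl in place of 2-methylphenyl on an aromatic carbon, sitting on an aromatic carbon, para to a large group. Going by the values given here, only one measured step touches this position: a 2.8-fold higher number from compound 2 to compound 3 (0.45 log units; beyond the scatter). Compound 1 carries a different side chain as well, so its value is not a single-step comparison. A six-membered aromatic ring of carbon only stays in place, so a step of modest size is expected: a 2.3-fold lower number from compound 3 to compound 4 (0.36 log units; beyond the scatter). Compound 4 is therefore estimated to give 1500 nM, with a likely range from 400 nM to 6000 nM.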

Compound 4, half-maximal effective concentration: 640 nM
Estimate against measurement, compound 4: 2.3-fold (0.37 log units) above, within the range that was stated.
By their numbers in this assay, from the lowest: compound 1; then compounds 4 and 2 (each within the scatter of the next); then compound 3.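

Replacing 2-methylphenyl with 4-chlorophenyl lowers the number (a 5.3-fold lower number from compound 3 to compound 4 (0.73 log units; beyond the scatter)), so in this assay this position distinguishes between two substituted phenyl rings of equal heavy-atom count. By contrast, 4-chlorophenyl and cyclopent-1-en-1-yl cannot be separated (a 1.9-fold lower number from compound 2 to compound 4 (0.27 log units; within the scatter)), even though one is an aromatic ring and the other is not. Nothing measured here explains these results.

This change swaps both the substituent and where it sits on the ring, so the two effects remain tangled. 4-Methylphenyl or 2-chlorophenyl would be the groups to separate them.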